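The source may hold more compounds than are shown below. What is called first, only, known or untested is meant among the compounds shown, and "the series" means these compounds.

For the measured compounds named here, in a functional assay on cells (Neutrophil, Homo sapiens) for inhibition, with a stated time of 10 min (a lower number here means a stronger inhibitor, a higher number a weaker inhibitor), compound 1 (`CCOC(=O)c1cnn(CC(C)O)c1NC(=O)Nc1ccc(F)cc1`) gives 0.2 nM and holds the lowest of the three numbers so far. Compound 3 (`CCOC(=O)c1cnn(C)c1NC(=O)NCc1ccccc1`) gives 1.3 nM and lies nearest to it, while compound 2 (`CCOC(=O)c1cnn(CC(O)CC)c1NC(=O)Nc1ccc(F)cc1`) gives 1.9 nM and lies furthest. Compound 4 (`CCOC(=O)c1cnn(CC(C)O)c1NC(=O)Nc1cccc(F)c1`) has not yet been measured. It departs from compound 1 in a single change (3-fluorophenyl in place of 4-fluorophenyl on an amide-type nitrogen), with 3-fluorophenyl in place of 4-fluorophenyl on an amide-type nitrogen, so the two have the same atoms, joined differently. Going by the values given here, no measured step touches this group. Among the compounds with values here, the only step between compounds that differ in one place (a 9.5-fold higher number from compound 1 to compound 2 (0.98 log units; beyond the scatter)) puts a methyl in place of hydrogen on a saturated chain carbon, so it bears on the new change only indirectly. It shows that one small edit to compound 1 moved the number beyond the scatter, but it says nothing about where the fluorine sits. Within the data shown here, with compound 1 at 0.2 nM as the lowest number so far, a modest rise is expected rather than a fall, probably smaller than that step. The expected step is a 2.5-fold higher number from compound 1 to compound 4 (0.40 log units; beyond the scatter) and it remains uncertain. For compound 4 the estimated value is 0.5 nM with 0.1 nM to 2.5 nM as the expected range.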

Compound 4, half-maximal inhibitory concentration: 0.0007 nM
The estimate for compound 4 lay 710-fold (2.85 log units) above the measured number; measured number outside the range, below it.
By their numbers in this assay, from the lowest: compound 4; then compound 1; then compounds 3 and 2 (each within the scatter of the next).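

In this assay, 3-fluorophenyl in place of 4-fluorophenyl on an amide-type nitrogen gives a 290-fold lower number from compound 1 to compound 4 (2.46 log units; beyond the scatter), with the heavy-atom count of the group unchanged and only the place of the fluorine differing. For the compounds shown here, the earlier step, a 9.5-fold higher number from compound 1 to compound 2 (0.98 log units; beyond the scatter), came from an edit to the saturated chain and showed only that the number responds there; this result shows that the fluorophenyl group on the urea side responds too, and far more strongly, so that where the fluorine sits on this ring matters greatly for the number. Nothing available here explains why this one change has so large an effect.

The compounds shown leave open whether the gain from 3-fluorophenyl carries over to other chains on the shared core, such as the one in compound 2, since this change appears on the background of compound 1 alone. They also leave open how an unsubstituted phenyl, or a chlorine or a methoxy group in place of the fluorine, would compare with compound 4 at 0.0007 nM.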